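Amide-nitrogen replacements on the shared core: estimate for compound 4

The compounds below may be only part of what the source reports. "The series", "measured", "known", "first", "only" and "open" are said of these compounds alone.

Compound 1, `CCOC(=O)C1=C(C)NC(C)=C(C(=O)OCC)C1c1ccc(OCC(=O)NCc2ccccc2)cc1`, gives 8.9% in a functional assay on the whole organism (strain Wistar) for inhibition, with Rattus norvegicus as the target, read by paw edema, with stated times of 30 min and 2 h, at a dose of 20 mg/kg; a lower number here means less inhibition, a higher number more inhibition at the dose given (going by the name of the read-out).
Compound 2, `CCOC(=O)C1=C(C)NC(C)=C(C(=O)OCC)C1c1ccc(OCC(=O)Nc2nc3ccccc3s2)cc1`, gives 64.5%.
Compound 3, `CCOC(=O)C1=C(C)NC(C)=C(C(=O)OCC)C1c1ccc(OCC(=O)NNC(=O)c2ccccc2)cc1`, gives 44.5%.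

Compound 1 stands lowest of the three measured: compound 3 lies a number 35.6 percentage points higher from compound 1 to compound 3 (beyond the scatter), and compound 2 further still, a number 55.6 percentage points higher from compound 1 to compound 2 (beyond the scatter). Compound 4, `CCOC(=O)C1=C(C)NC(C)=C(C(=O)OCC)C1c1ccc(OCC(=O)NNC(=O)c2ccsc2Cl)cc1`, has not yet been measured. It differs from compound 1 in one place: a group of 9 heavy atoms (5 carbon, 1 nitrogen, 1 oxygen, 1 sulfur, 1 chlorine; one five-membered aromatic ring with 1 hetero atom) in place of a group of 7 heavy atoms (7 carbon; one six-membered aromatic ring of carbon only), on an amide-type nitrogen. The step bearing most closely on it is a number 35.6 percentage points higher from compound 1 to compound 3 (beyond the scatter), as the benzamido group of compound 3 is the nearest analogue of the entering group; a number 55.6 percentage points higher from compound 1 to compound 2 (beyond the scatter) shows a second replacement of the benzyl at this position also raising the read-out strongly. A large rise in this assay is therefore expected, a number 33.1 percentage points higher from compound 1 to compound 4 (beyond the scatter). Compound 4 is estimated at 42%, within 26% to 58%.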

Compound 4, a percentage reported as inhibition, in the whole organism at one dose (the size of the read-out at that dose, not a potency): 52.8%
The estimate for compound 4 lay 10.8 percentage points below the measured number; the range from low to high includes it.
By their numbers in this assay, from the lowest: compound 1; then compounds 3 and 4 (each within the scatter of the next); then compound 2.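

With 2-chlorothiophen-3-yl in place of phenyl on the carbonyl carbon, the step is within the scatter (a number 8.3 percentage points higher from compound 3 to compound 4 (within the scatter)), so this ring can differ without a read-out separable from that of compound 3. The large gain over benzyl recurs with this second ring (a number 43.9 percentage points higher from compound 1 to compound 4 (beyond the scatter)), yet the 1,3-benzothiazol-2-yl group keeps a modest lead (a number 11.7 percentage points lower from compound 2 to compound 4 (beyond the scatter)). No measurement at hand accounts for these differences.

The compounds shown do not separate the chlorine from the thiophene ring, as a plain thiophen-3-yl would. As far as these compounds go, whether an amine or a carboxylic acid on this ring would keep the read-out also stays open.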